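The compounds below may be only part of what the source reports. "The series", "measured", "known", "first", "only" and "open" are said of these compounds alone.

Of the compounds shown here, three built on one shared core have been measured in an assay on CHO cells for displacement of a labelled ligand from Substance-P receptor (Homo sapiens), read by scintillation counting; a higher number here means a weaker inhibitor, a lower number a stronger inhibitor. Compound 1 `Cc1cc(F)ccc1[C@H]1C[C@@H](N2CCCC2)CCN1C(=O)N(C)Cc1cc(C(F)(F)F)cc(C(F)(F)F)c1` gives 0.275 nM. Compound 2 `Cc1cc(F)ccc1[C@H]1C[C@@H](N2CCCC2)CCN1C(=O)N(C)[C@H](C)c1cc(C(F)(F)F)cc(C(F)(F)F)c1`, which carries a methyl in place of a hydrogen on the chain carbon bound to the amide-type nitrogen and the aromatic ring, gives 0.141 nM. With the same atoms and bonds as compound 2 but one ring stereocentre drawn the other way, compound 3 `Cc1cc(F)ccc1[C@H]1C[C@H](N2CCCC2)CCN1C(=O)N(C)[C@H](C)c1cc(C(F)(F)F)cc(C(F)(F)F)c1` gives 0.2 nM. Compound 2 shows the lowest of the three numbers, yet both steps to it stay inside the usual scatter: a 2.0-fold lower number from compound 1 to compound 2 (0.29 log units; within the scatter), and a 1.4-fold higher number from compound 2 to compound 3 (0.15 log units; within the scatter). Because (the fact that compounds 2 and 3 differ only in the configuration as drawn), the second step shows that the drawn configuration at that ring carbon makes little difference here.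

Compound 4 `COCCN[C@H]1CCN(C(=O)N(C)[C@H](C)c2cc(C(F)(F)F)cc(C(F)(F)F)c2)[C@@H](c2ccc(F)cc2C)C1` has not yet been measured. It differs from compound 2 in one place: (2-methoxyethyl)amino in place of pyrrolidin-1-yl on a saturated ring carbon. Neither measured step exchanges one group for another at this ring carbon; the nearest comparison is the configuration change from compound 2 to compound 3, which stayed within the scatter. Replacing a ring with an open chain that brings a hydrogen-bond donor has no precedent among these three, so the expectation is loose: a modest step, most likely toward a higher number, is expected, a 3.2-fold higher number from compound 2 to compound 4 (0.50 log units; beyond the scatter). Compound 4 is estimated at 0.45 nM, expected to fall between 0.1 nM and 2 nM.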

Compound 4, inhibition constant: 0.209 nM
Compound 4: middle estimate off by 2.2-fold (0.33 log units), on the high side, within the range that was stated.
By their numbers in this assay, from the lowest: compounds 2, 3, 4 and 1 (each within the scatter of the next).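

In this assay, going by these compounds alone, putting (2-methoxyethyl)amino in place of pyrrolidin-1-yl on the saturated ring carbon gives a 1.5-fold higher number from compound 2 to compound 4 (0.17 log units; within the scatter), the first exchange of one group for another at this position. Until now, this carbon had been probed only by a change of configuration, whereas here the ring gives way to an open chain with a hydrogen-bond donor and an oxygen, and the number stays within the scatter of that of compound 2. Nothing measured here explains why these two different groups give such similar numbers.

Both groups have 5 heavy atoms and are joined to the ring carbon through nitrogen, so the compounds shown do not tell whether a much longer chain, a carboxylic acid or a bare amino group on this carbon would give a similar number. They also leave open whether (2-methoxyethyl)amino would behave the same way with this ring carbon drawn in the other configuration, since that change is shown only with pyrrolidin-1-yl in place.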